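This account rests on a few compounds, and the source may have more. Where it says the series, first, only, none or still open, it means among the compounds named here.

In an in vitro functional assay on 1321-N1 cells for agonist activity at P2Y purinoceptor 2 (Homo sapiens), read by scintillation proximity assay and inositol phosphate accumulation (on this read-out lower numbers stand for an effect already at smaller amounts and higher numbers for an effect only at larger amounts of compound), compound 1, `O=c1ccn([C@@H]2O[C@H](COP(=O)(O)O)[C@@H](O)[C@H]2O)c(SCCc2ccccc2)n1`, gives 1300 nM. Compound 2, `O=c1ccn([C@@H]2O[C@H](COP(=O)(O)O)[C@@H](O)[C@H]2O)c(SCc2ccccc2)n1`, gives in this assay >= 100000 nM, which is a limit of the assay and not a number, so compound 2 stands only at a bound on the numbers shown. For the measured compounds named here, the single measured step, an at least 76-fold higher number from compound 1 to compound 2 (1.88 log units; beyond the scatter), is itself known only as a lower bound because the limit of >= 100000 nM in this assay, at which 1 of the 2 values shown sits, cuts it off. Compound 3, `CCCSc1nc(=O)ccn1[C@@H]1O[C@H](COP(=O)(O)O)[C@@H](O)[C@H]1O`, differs from compound 2 by ethyl in place of phenyl on a saturated chain carbon bound to a sulfur. Going by the values given here, no measured step covers this exact change; the one step known, from the phenethyl to the benzyl group, was large and towards weaker effect, and it gives no sign that shortening the group to propyl recovers potency. Compound 3 is therefore expected to stay weak, with an estimated step of an at least 2.0-fold lower number from compound 2 to compound 3 (0.30 log units; that floor lies within the scatter) that may be no real change at all. The estimate for compound 3 in this assay is 50000 nM, within a range of 5000 nM to 200000 nM, and a further limit rather than a number is considered fairly likely.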

Compound 3, half-maximal effective concentration: 4800 nM
Compound 3: middle estimate off by 10-fold (1.02 log units), on the high side; measured number below the stated range.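

Taking the phenyl away from the benzyl group and putting ethyl in its place, on a saturated chain carbon bound to a sulfur, gives an at least 20-fold lower number from compound 2 to compound 3 (1.31 log units; beyond the scatter), so the loss of effect seen with the benzyl group does not extend to every small group on the sulfur, and a phenyl ring is not needed for an effect in this assay. The ring-free propyl group also comes fairly close to the phenethyl group, with only a 3.7-fold higher number from compound 1 to compound 3 (0.57 log units; beyond the scatter), so among these three compounds the size of the group does not order the numbers, and compound 2, with the benzyl group, is the one that goes against any such order. The recovery from the benzyl group can be stated only as a lower bound, and its true size stays unknown because the step is cut off by this: the limit of >= 100000 nM in this assay, at which 1 of the 3 values shown sits.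

The compounds shown leave open whether the effect at this place follows chain length in the ring-free series, as a shorter ethyl or a longer butyl chain on the sulfur would show, and whether a 3-phenylpropyl group would go beyond the phenethyl group. They also leave open how an amine or a carboxylic acid at the end of the chain would fare.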